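Changing the Group on the Aromatic Nitrogen of Compound 3

The source may report more compounds than this note shows. Statements on the series, on what has been measured and on what is new or still open speak of the compounds shown alone.

In a functional assay on HepG2 cells (Homo sapiens) for antiproliferative activity, read by MTT assay (a higher number here means a weaker inhibitor, a lower number a stronger inhibitor), compound 3 `CCc1ccccc1-n1cc(COc2ccc(/C=C/C(=O)c3cc4c(cc3O)OC(C)(C)CC4)cc2)nn1` gives 115000 nM, within the scatter of compound 2 `Cc1c(-n2cc(COc3ccc(/C=C/C(=O)c4cc5c(cc4O)OC(C)(C)CC5)cc3)nn2)cccc1[N+](=O)[O-]` at 109000 nM. A third relative, compound 1 `CC1(C)CCc2cc(C(=O)/C=C/c3ccc(OCc4cn(-c5ccc(Br)cc5)nn4)cc3)c(O)cc2O1`, is reported as "not active" (no number reported). Compound 4 `CC1(C)CCc2cc(C(=O)/C=C/c3ccc(OCc4cn(Cc5ccc([N+](=O)[O-])cc5)nn4)cc3)c(O)cc2O1` carries 4-nitrobenzyl in place of 2-ethylphenyl on an aromatic nitrogen. Within the data shown here, only one measured step bears on this change: a 1.1-fold higher number from compound 2 to compound 3 (0.02 log units; within the scatter), an exchange on that same nitrogen that stays within the scatter. Among the measured compounds shown here, no measured compound carries a benzyl group, so this is a loose guide, and compound 1 shows that a reading without a number remains possible. The estimated change is a 1.2-fold lower number from compound 3 to compound 4 (0.08 log units; within the scatter), with no shift beyond the scatter expected. For compound 4 the expected value is 95000 nM, with an estimated range from 35000 nM to 190000 nM.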

Compound 4, half-maximal inhibitory concentration: 109000 nM
The estimate for compound 4 lay 1.1-fold (0.06 log units) below the measured number, within the range that was stated.
By their numbers in this assay, from the lowest: compounds 2, 4 and 3 (each within the scatter of the next).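

Among these compounds, the first benzyl group on this aromatic nitrogen, 4-nitrobenzyl, stays within the scatter of both directly attached aryl relatives in this assay (a 1.1-fold lower number from compound 3 to compound 4 (0.02 log units; within the scatter)) and (no change at the digits printed from compound 2 to compound 4 (within the scatter)). Thus, among compounds 2, 3 and 4, this position accepts the added carbon link and the nitro group's two hydrogen-bond acceptors without a shift beyond the scatter. No evidence is available to explain this result. The compounds shown leave open whether an amine, a carboxylic acid or a longer chain on this nitrogen would change the number beyond the scatter.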